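Replacing a nitrile with a chloride on the sulfonyl aryl ring

The compounds below may be only part of what the source reports. "The series", "measured", "known", "first", "only" and "open" are said of these compounds alone.

Measured compounds:
compound 1, `CC1CCN(C2CCN(S(=O)(=O)c3cn(C)c(=O)n(C)c3=O)CC2)CC1`: in a functional assay on DLD-1 cells (Homo sapiens) for antiproliferative activity, read by CellTiter-Glo, with a stated time of 72 h (a higher number here means a weaker inhibitor, a lower number a stronger inhibitor), compound 1 gives > 5000 nM
compound 2, `CC1CCN(C2CCN(S(=O)(=O)c3ccc(C#N)cc3)CC2)CC1`: in this assay compound 2 gives 2800 nM
compound 3, `CC1CCN(C2CCN(S(=O)(=O)c3ccc(-c4ccccc4F)cc3)CC2)CC1`: in this assay compound 3 gives 5 nM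

The value of compound 1 is a limit of this assay, not a number (the limit of > 5000 nM in this assay, at which 1 of the 3 values shown sits). Among the two numbers that are given, compound 2 has the highest, and its nearest neighbour is compound 3, which differs from it by a 560-fold lower number from compound 2 to compound 3 (2.75 log units; beyond the scatter), where a 2-fluorophenyl stands in place of cyano on an aromatic carbon.

The unmeasured compound 4, `CC1CCN(C2CCN(S(=O)(=O)c3cccc(Cl)c3)CC2)CC1`, differs from compound 2 in the same region: 3-chlorophenyl in place of 4-cyanophenyl on a sulfonyl sulfur. Within the data shown here, only the step from compound 2 to compound 3 bears on this change, and it shows that the group on the aryl ring attached to the sulfonyl sulfur can move the result a long way. Compound 4 carries neither the cyano of compound 2 nor the 2-fluorophenyl of compound 3, so a smaller shift is expected than a 560-fold lower number from compound 2 to compound 3 (2.75 log units; beyond the scatter), still toward a lower number. Compound 4 is therefore expected to give 1000 nM in this assay, within 200 nM to 5000 nM, a step of a 2.8-fold lower number from compound 2 to compound 4 (0.45 log units; beyond the scatter) that remains an estimate.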

Compound 4, half-maximal inhibitory concentration: > 5000 nM
Compound 4: no number, only a limit (the forecaster's own chance of this, stated with the estimate: 15%); middle value at least 5.0-fold (0.69 log units) away from the limit.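

The change to 3-chlorophenyl did not bring the low number of compound 3 within reach in this assay, and the step reads an at least 1.7-fold higher number from compound 2 to compound 4 (0.25 log units; that floor lies within the scatter), so it gives only a floor and sets no firm order between the two compounds. Compound 4 gives a limit and not a number, and it stands at that limit with compound 1: the limit of > 5000 nM in this assay, at which 2 of the 4 values shown sit. On this sulfonyl sulfur, then, an aryl ring alone does not secure a low number, as compound 2 gives 2800 nM while compound 3, with its 2-fluorophenyl group on the ring, gives 5 nM.

The compounds shown do not separate the loss of the nitrile from the arrival of the chlorine, since 3-chlorophenyl and 4-cyanophenyl differ in more than the group alone. On these data alone, it also remains open how a methoxy group, an amine or a carboxylic acid on this aryl ring would read, and whether a plain phenyl would serve in place of the 2-fluorophenyl of compound 3.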